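Trifluoromethyl for Chloro in a Glutamate Receptor Agonist Series

The source may report more compounds than this note shows. Statements on the series, on what has been measured and on what is new or still open speak of the compounds shown alone.

Two measured compounds share one core and differ only in the group on a saturated ring carbon. Compound 1, `COc1ccc(F)cc1C1CCN(c2ccn3c(CC4CC4)nnc3c2Cl)CC1`, gives 283% in a functional assay on CHO cells for agonist activity at metabotropic glutamate receptor 2 (Homo sapiens), read by scintillation counting and GTPgammaS binding, with a stated time of 30 min; on this read-out higher numbers stand for larger maximal responses and lower numbers for smaller maximal responses. Compound 2, `COc1c(F)cccc1C1CCN(c2ccn3c(CC4CC4)nnc3c2Cl)CC1`, gives 336% in this assay, the higher of the two numbers; the step is a number 53 percentage points higher from compound 1 to compound 2 (beyond the scatter), with 3-fluoro-2-methoxyphenyl in place of 5-fluoro-2-methoxyphenyl on a saturated ring carbon. Compound 3, `COc1c(F)cccc1C1CCN(c2ccn3c(CC4CC4)nnc3c2C(F)(F)F)CC1`, keeps the 3-fluoro-2-methoxyphenyl group of compound 2 and differs from it by trifluoromethyl in place of chloro on an aromatic carbon. For the measured compounds named here, no measured step touches this position on the core: the only step known, a number 53 percentage points higher from compound 1 to compound 2 (beyond the scatter), concerns the saturated ring carbon and gives no guidance here. The expectation therefore rests on compound 2 alone. Compound 3 is estimated at 330% in this assay, within 240% to 420%. The implied step a number 6 percentage points lower from compound 2 to compound 3 (within the scatter) is expected to be none beyond the scatter.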

Compound 3, largest response reached (Emax), in percent of the reference or control that the assay uses: 528%
Beside the measured number, compound 3's estimate is 198 percentage points below it, and the stated range ends below it.
By their numbers in this assay, from the lowest: compound 1; then compound 2; then compound 3.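

The aromatic carbon that carries chloro in compound 2 turns out to be a strong lever on the maximal response, which the earlier step on the saturated ring carbon could not reveal. In this assay, trifluoromethyl in place of chloro on this carbon gives a number 192 percentage points higher from compound 2 to compound 3 (beyond the scatter) and so places compound 3 highest of the three compounds. Chloro is therefore not needed here for a high maximal response, at least alongside the 3-fluoro-2-methoxyphenyl group, and no measurement at hand explains the rise.

On these data alone, this reading rests on a single pair, so it remains open whether the same change would raise the response with the 5-fluoro-2-methoxyphenyl group of compound 1. As far as these compounds go, it is also open how a nitrile, a methyl group or an amine on this aromatic carbon would compare with trifluoromethyl.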